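This account rests on a few compounds, and the source may have more. Where it says the series, first, only, none or still open, it means among the compounds named here.

Three compounds have been measured so far in an ADME assay on L132 cells (Homo sapiens) for cytotoxicity, read by MTT assay, with a stated time of 48 h (a higher number here means a weaker inhibitor, a lower number a stronger inhibitor), and each result is a limit:

- Compound 1 `C/C(=C\CC/C(C)=C/CC[C@@H]1[C@@]2(C)CCC(=O)C(C)(C)[C@H]2CC[C@@]1(C)O)CC/C=C(\C)C(=O)OCc1cn(-c2ccccc2[N+](=O)[O-])nn1` gives > 150000 nM (a limit)
- Compound 2 `C/C(=C\CC/C(C)=C/CC[C@@H]1[C@@]2(C)CCC(=O)C(C)(C)[C@H]2CC[C@@]1(C)O)CC/C=C(\C)C(=O)OCc1cn(-c2ccccc2Br)nn1` gives > 150000 nM (a limit)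
- Compound 3 `C/C(=C\CC/C(C)=C/CC[C@@H]1[C@@]2(C)CCC(=O)C(C)(C)[C@H]2CC[C@@]1(C)O)CC/C=C(\C)C(=O)OCc1cn(-c2ccc(F)c(Cl)c2)nn1` gives > 150000 nM (a limit)

Compound 3 stands level with nothing more exact than its reading of > 150000 nM, which is a limit and not a number.

The next compound, compound 4 `C/C(=C\CC/C(C)=C/CC[C@@H]1[C@@]2(C)CCC(=O)C(C)(C)[C@H]2CC[C@@]1(C)O)CC/C=C(\C)C(=O)OCc1cn(-c2cccc(Br)c2)nn1`, keeps the shared core and changes only the group on the aromatic nitrogen. The change is 3-bromophenyl in place of 3-chloro-4-fluorophenyl on an aromatic nitrogen, with 3-bromophenyl in place of 3-chloro-4-fluorophenyl.

The closest measured change is a step that the two limits leave unreadable from compound 2 to compound 3, which swaps the group at the same place. Also relevant are a step that the two limits leave unreadable from compound 1 to compound 3, at that place too, and a step that the two limits leave unreadable from compound 1 to compound 2, on an aromatic carbon. None of these has a readable size, so none offers a size or direction to carry over.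

Compound 4 is expected to stay at the limit as well, given the limit of > 150000 nM in this assay, at which 3 of the 3 values shown sit, for this series. The expected change is a step that the limit leaves unreadable from compound 3 to compound 4 and no direction can be named for it. For compound 4 the estimate is 160000 nM, with an expected range from 90000 nM to 300000 nM in this assay once measured.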

Compound 4, half-maximal inhibitory concentration: > 150000 nM
Compound 4 ended at the assay's limit; the forecaster's own chance of this, stated with the estimate: 80%; the middle value is on the limit's open side.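

All four compounds read only as limits in this assay, not as numbers, so no step between compound 1, compound 2, compound 3 and compound 4 can be read: the limit of > 150000 nM in this assay, at which 4 of the 4 values shown sit.

The compounds shown leave open how far each one lies past its limit, and whether changing the group on the aromatic nitrogen alters the reading at all.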